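The source may hold more compounds than are shown below. What is called first, only, known or untested is meant among the compounds shown, and "the series" means these compounds.

Measured so far in a functional assay on the whole organism (strain STD-dd) with Mus musculus as the target, in the maximal electroshock model, with a stated time of 2 h; on this read-out higher numbers stand for an effect only at larger amounts of compound and lower numbers for an effect already at smaller amounts:
compound 1 `CCNS(=O)(=O)Cc1noc2ccc(F)cc12` gives 32 mg/kg
compound 2 `CCNS(=O)(=O)Cc1noc2ccc(Cl)cc12` gives 21 mg/kg
compound 3 `NS(=O)(=O)Cc1noc2ccc(Br)cc12` gives 14 mg/kg

Compound 3 has the lowest number of the three in this assay; its value lies within the scatter of compound 2 and beyond the scatter of compound 1. Compound 4 `CCNS(=O)(=O)Cc1noc2ccc(Br)cc12` differs from compound 3 in one place: ethyl in place of hydrogen on a sulfonamide nitrogen. Going by the values given here, no measured pair isolates this change. Among the compounds with values here, the only step between compounds that differ in one place is a 1.5-fold lower number from compound 1 to compound 2 (0.18 log units; within the scatter), an exchange of halogen that leaves the sulfonamide untouched. Compound 2 and compound 3 differ in two places, the halogen and the substituent on the sulfonamide nitrogen, and their numbers lie within the scatter of each other, which hints that the combined change is small, though the two parts cannot be separated. The step from compound 3 to compound 4 is therefore expected to be a 1.3-fold higher number from compound 3 to compound 4 (0.11 log units; within the scatter), not beyond the scatter. The estimate for compound 4 is 18 mg/kg, with a range from 9 mg/kg to 36 mg/kg.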

Compound 4, dose for half-maximal effect: 18 mg/kg
The estimate for compound 4 equals the measured number at the digits printed; low and high end bracket the measured number.
By their numbers in this assay, from the lowest: compounds 3, 4, 2 and 1 (each within the scatter of the next, the first and the last beyond it).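

In this assay, the sulfonamide nitrogen now has a pair that differs in this place alone: a 1.3-fold higher number from compound 3 to compound 4 (0.11 log units; within the scatter) shows that, with bromo on the core, ethyl and hydrogen cannot be told apart on this read-out. With the ethylamino sulfonamide held fixed, the halogen exchange now covers fluoro, chloro and bromo, and neither a 1.2-fold lower number from compound 2 to compound 4 (0.07 log units; within the scatter) nor a 1.8-fold lower number from compound 1 to compound 4 (0.25 log units; within the scatter) leaves the scatter, so these exchanges show no measurable effect here. Nothing available offers an explanation for these small steps.

On these data alone, it remains open whether a longer chain such as butyl, or a ring such as piperidine, on the sulfonamide nitrogen would stay as close to hydrogen as ethyl does. Also open, as far as these compounds go, is whether methoxy or trifluoromethyl in place of the halogen would keep the number within the scatter.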